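From 4-methylbenzyl to 4-methoxybenzyl in compound 4

A few compounds are considered here, and "the series" means these few. Any claim that something is new, unique, unknown or untested is made for them only; others in the source may bear on it.

In a physicochemical assay for solubility, with a stated time of 3 days, at pH 2 (on this read-out higher numbers stand for higher solubility and lower numbers for lower solubility), compound 1 `NC(=O)c1ccc2[nH]c(-c3ccc(OCCCO)cc3)nc2c1` gives 185000 nM as a measured number. Compound 2 `NC(=O)c1ccc2[nH]c(-c3ccc(OCCC4CCCCN4Cc4ccccc4)cc3)nc2c1` gives > 400000 nM as a limit of the assay and not a number. Compound 3 `Cc1ccc(CN2CCCCC2CCOc2ccc(-c3nc4cc(C(N)=O)ccc4[nH]3)cc2)cc1` gives > 400000 nM as a limit too and not a number. Compound 3 therefore has no number of its own and stands at the limit of > 400000 nM in this assay, at which 2 of the 3 values shown sit, with nothing finer to read.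

Compound 4 `COc1ccc(CN2CCCCC2CCOc2ccc(-c3nc4cc(C(N)=O)ccc4[nH]3)cc2)cc1` follows from compound 3 through methoxy in place of methyl on an aromatic carbon in which methoxy stands in place of methyl on an aromatic carbon, para to a large group. Among the measured compounds shown here, the one measured step that bears on this, methyl in place of hydrogen on an aromatic carbon, is a step that the two limits leave unreadable from compound 2 to compound 3 and offers no size to carry over.

For compound 4 the expected step of a number no higher from compound 3 to compound 4 (the limit leaves the size open) in this assay is none beyond the scatter and has no expected direction. Compound 4 is estimated at 400000 nM with an expected range from 200000 nM to 800000 nM and a report as a limit is the likeliest outcome.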

Compound 4, solubility: > 400000 nM
Compound 4: a limit, no number (the forecaster's own chance of this, stated with the estimate: 75%); the middle value sits exactly at the limit.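

No new step can be read from compound 3 to compound 4 or from compound 2 to compound 4, because compound 2, compound 3 and compound 4 are all reported as a limit and not a number: the limit of > 400000 nM in this assay, at which 3 of the 4 values shown sit.

The compounds shown leave open whether compound 2, compound 3 and compound 4 differ at all in this assay, and by how much.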